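An Oxirane in Place of Isobutyl

The compounds below may be only part of what the source reports. "The series", "measured", "known", "first", "only" and "open" are said of these compounds alone.

In a functional assay on MCF7 cells (Homo sapiens) for inhibition, read by sulforhodamine B assay, with a stated time of 48 h, tested at 50 uM (a higher number here means more inhibition of growth at the concentration tested, a lower number less inhibition of growth), compound 1 `COc1cc2c(cc1CCC(C)C)C(=O)C[C@@H](c1ccc(O)cc1)O2` gives 81%, the highest of the three numbers at hand. Compound 2 `COc1ccc([C@@H]2C/C(=N/OCc3cn(-c4ccc(C(=O)c5ccccc5)cc4)nn3)c3cc(CC=C(C)C)c(OC)cc3O2)cc1` gives 41% and compound 3 `COc1ccc([C@@H]2C/C(=N/OCc3cn(-c4ccc(C#N)cc4)nn3)c3cc(CC=C(C)C)c(OC)cc3O2)cc1` gives 40%. Among the measured compounds shown here, the only measured step, a number 1 percentage points lower from compound 2 to compound 3 (within the scatter), is cyano in place of benzoyl on an aromatic carbon and lies within the scatter, so it does not bear on the change considered here. Compound 4 `COc1cc2c(cc1CC1OC1(C)C)C(=O)C[C@@H](c1ccc(O)cc1)O2` differs from compound 1 as follows: 3,3-dimethyloxiran-2-yl in place of isobutyl on a saturated chain carbon bound to an aromatic carbon. For the measured compounds named here, no measured step covers this exchange, so the expectation rests on compound 1 alone, at 81%, and a moderate fall is anticipated with wide uncertainty. The expected step is a number 16 percentage points lower from compound 1 to compound 4 (beyond the scatter). For compound 4 the estimated value is 65%, within an expected range of 40% to 88%.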

Compound 4, percent growth inhibition at one concentration: 98%
Compound 4: the middle estimate sits 33 percentage points below what was measured; measured number above the stated range.
By their numbers in this assay, from the lowest: compounds 3 and 2 (each within the scatter of the next); then compound 1; then compound 4.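

At this place, on a saturated chain carbon bound to an aromatic carbon, 3,3-dimethyloxiran-2-yl not only replaces isobutyl without loss but raises the growth inhibition in this assay (a number 17 percentage points higher from compound 1 to compound 4 (beyond the scatter)). Unlike the exchange of benzoyl for cyano, this change moves the read-out beyond the scatter, although the two steps lie at different places on different compounds. Nothing at hand explains the rise. The compounds shown leave open whether the ring or its oxygen accounts for the change. They also leave open how an amine or a longer chain would read at this place.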